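Removing a Methoxy Group From a Benzylamine Side Chain

The source may report more compounds than this note shows. Statements on the series, on what has been measured and on what is new or still open speak of the compounds shown alone.

Compound 2 `COc1ccc(CNc2nc(SC)nc3ccccc23)cc1` was tested in a functional assay on HTB-54 cells (Homo sapiens) for cytotoxicity, read by MTT assay, with a stated time of 72 h (on this read-out lower numbers stand for stronger inhibition of growth and higher numbers for weaker inhibition of growth), and for compound 2 the result is a limit of the assay, > 100000 nM, not a number. Compound 2 thus stands at the limit of > 100000 nM in this assay, at which 1 of the 3 values shown sits. Of the other compounds tested, compound 1 `C[Se]c1nc(N)c2ccccc2n1` gives 88700 nM in this assay, while for compound 3 `C[Se]c1nc([Se]C)c2cccnc2n1` the result in this assay is "not determined" (no result reported). Compound 4 `CSc1nc(NCc2ccccc2)c2ccccc2n1` differs from compound 2 by hydrogen in place of methoxy on an aromatic carbon. Going by the values given here, no measured step describes this change, so in this assay the step from compound 2 to compound 4 is expected to be none beyond the scatter, leaving a result at or near the limit likely. Compound 4 is estimated at 90000 nM, within a range from 40000 nM to 200000 nM, which amounts to an expected step of an at least 1.1-fold lower number from compound 2 to compound 4 (0.04 log units; that floor lies within the scatter).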

Compound 4, concentration for total growth inhibition: 82300 nM
Estimate against measurement, compound 4: 1.1-fold (0.04 log units) above, and the stated range covers the measured number.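

On this aromatic carbon, para to a large group, hydrogen in place of methoxy gives the first step read at this position in this assay: an at least 1.2-fold lower number from compound 2 to compound 4 (0.08 log units; that floor lies within the scatter). Without the methoxy group, compound 4 gives a number rather than a limit, but the printed floor does not show a change beyond the scatter. The true size of the step cannot be read, as compound 2 has only a limit: the limit of > 100000 nM in this assay, at which 1 of the 4 values shown sits.

On these data alone, whether a hydroxyl group, a chlorine atom or a longer ether chain on that carbon would move the number beyond the scatter stays open. The compounds shown also leave open how an amine or a carboxylic acid would behave there.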